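From Isopropyl to Cyclopropyl on an Amide-Type Nitrogen

The source may hold more compounds than are shown below. What is called first, only, known or untested is meant among the compounds shown, and "the series" means these compounds.

Measured in an in vitro ADME assay on microsomes from liver (Homo sapiens) for pharmacokinetics, read by LC-MS, with a stated time of 10 min, tested at 1 uM; a lower number here means slower removal, a higher number faster removal of the compound:
- compound 1 `Cc1ccc(NC(=O)[C@H]2CN(C)C[C@@H]2c2ccc(/C=C/C(=O)Nc3ccccc3N)cc2)cc1` gives 15 mL/min/kg
- compound 2 `Cc1cccc(NC(=O)[C@H]2CN(C)C[C@@H]2c2ccc(/C=C/C(=O)Nc3ccccc3N)cc2)c1` gives 14 mL/min/kg
- compound 3 `CC(C)NC(=O)[C@H]1CN(C)C[C@@H]1c1ccc(/C=C/C(=O)Nc2ccccc2N)cc1` gives 8 mL/min/kg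

Compound 3 stands at 8 mL/min/kg in this assay, a value within the scatter of those of the other two measured compounds. The unmeasured compound 4 `CN1C[C@H](C(=O)NC2CC2)[C@@H](c2ccc(/C=C/C(=O)Nc3ccccc3N)cc2)C1` differs from it in one place: cyclopropyl in place of isopropyl on an amide-type nitrogen. This puts cyclopropyl in place of isopropyl on an amide-type nitrogen.

Going by the values given here, no measured compound carries cyclopropyl, so no measured step shows this exchange directly. The nearest evidence comes from changes on the same nitrogen. Replacing a methylphenyl group with isopropyl gave a 1.9-fold lower number from compound 1 to compound 3 (0.27 log units; within the scatter) and also a 1.8-fold lower number from compound 2 to compound 3 (0.24 log units; within the scatter), while moving the methyl group gave a 1.1-fold lower number from compound 1 to compound 2 (0.03 log units; within the scatter). All three steps lie within the scatter, and none offers a direction for the exchange at hand.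

A change within the scatter is therefore expected, and the estimated step reads no change at the digits printed from compound 3 to compound 4 (within the scatter). The estimate for compound 4 is 8 mL/min/kg, with an expected range from 4.5 mL/min/kg to 14 mL/min/kg.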

Compound 4, clearance: 10 mL/min/kg
Compound 4: middle estimate off by 1.3-fold (0.10 log units), on the low side; the measured number falls inside the stated range.
By their numbers in this assay, from the lowest: compounds 3, 4, 2 and 1 (each within the scatter of the next).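

In this assay, the exchange on the amide-type nitrogen brings in a three-membered carbon ring where isopropyl stood, with the heavy-atom count unchanged, and it gives a 1.3-fold higher number from compound 3 to compound 4 (0.10 log units; within the scatter). This is the first direct reading of cyclopropyl at this position, and its steps from the two methylphenyl compounds, a 1.4-fold lower number from compound 2 to compound 4 (0.15 log units; within the scatter) and a 1.5-fold lower number from compound 1 to compound 4 (0.18 log units; within the scatter), also stay within the scatter, so no step among these four compounds separates the groups on this nitrogen, whether they are open-chain, a small carbon ring or methylphenyl. Nothing measured here explains why these numbers lie so close together.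

The compounds shown leave open whether any group on this nitrogen would produce a step beyond the scatter, for instance a longer alkyl chain, a chain ending in an amine or a carboxylic acid. They also leave open whether the closeness seen with cyclopropyl and isopropyl would hold for a larger carbon ring such as cyclohexyl.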